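Short Bromo Tail in Place of a Ketone-Bearing Chain

The source may report more compounds than this note shows. Statements on the series, on what has been measured and on what is new or still open speak of the compounds shown alone.

Compound 1 `CCCn1c(=O)c2nc(-c3ccc(OCC(=O)NCCN=C(S)Nc4ccc(OC)cc4)cc3)[nH]c2n(CCC)c1=O` and compound 2 `CCCn1c(=O)c2nc(-c3ccc(OCC(=O)NCCNC(=O)CCCCC(C)=O)cc3)[nH]c2n(CCC)c1=O` share one core and differ only in a tail group. In an assay on brain for binding affinity to adenosine receptor A1 (Rattus norvegicus), read by radioligand binding (on this read-out lower numbers stand for stronger inhibition and higher numbers for weaker inhibition), compound 1 gives 33.2 nM, and compound 2 gives 44 nM; the step of a 1.3-fold higher number from compound 1 to compound 2 (0.12 log units; within the scatter) shows that exchanging this tail hardly moved the number, so compound 2 stands close beside compound 1 on the two numbers available. Compound 3 `CCCn1c(=O)c2nc(-c3ccc(OCC(=O)NCCNC(=O)CBr)cc3)[nH]c2n(CCC)c1=O` carries the change (bromo in place of 3-acetylpropyl on a saturated chain carbon bound to a carbonyl carbon). Because a 1.3-fold higher number from compound 1 to compound 2 (0.12 log units; within the scatter) was small, a step of similar size is expected, a 1.1-fold lower number from compound 2 to compound 3 (0.04 log units; within the scatter). Compound 3 is therefore estimated at 40 nM, with a range from 15 nM to 110 nM.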

Compound 3, inhibition constant: 17.6 nM
Compound 3: the middle estimate sits 2.3-fold (0.36 log units) above what was measured, within the range that was stated.
By their numbers in this assay, from the lowest: compounds 3, 1 and 2 (each within the scatter of the next, the first and the last beyond it).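

In this assay, within the data shown here, a lone bromo on the saturated chain carbon bound to a carbonyl carbon does no harm, with a 2.5-fold lower number from compound 2 to compound 3 (0.40 log units; beyond the scatter) as the first step here to pass the scatter, if only modestly. The other step, a 1.9-fold lower number from compound 1 to compound 3 (0.28 log units; within the scatter) and so no real difference, shows that the much larger ring-bearing tail and this short one cannot be told apart. Nothing measured here explains either step. Still open, as far as these compounds go, is whether chloro, plain hydrogen or a longer bromoalkyl chain at this place would give a similar number.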